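Methyl to Ethyl at One Position of Compound 3

The source may report more compounds than this note shows. Statements on the series, on what has been measured and on what is new or still open speak of the compounds shown alone.

Compound 1 `Cc1cc(NCCN(C)C)nc2ccc(NC(=O)c3ccc(Cl)c(Cl)c3)cc12` gives 2550 nM.
Compound 2 `CCN(CC)CCNc1cc(C)c2cc(NC(=O)c3ccc(Cl)c(Cl)c3)ccc2n1` gives 1420 nM.
Compound 3 `CCN1CCN(c2cc(C)c3cc(NC(=O)c4ccccc4C)ccc3n2)CC1` gives 10900 nM.

In a functional assay on MCF7 cells (Homo sapiens) for antiproliferative activity, read by MTT assay, with a stated time of 72 h (a higher number here means a weaker inhibitor, a lower number a stronger inhibitor), compound 3 stands at the highest of the three numbers, beyond the scatter from both compound 1 and compound 2. Compound 4 `CCc1ccccc1C(=O)Nc1ccc2nc(N3CCN(CC)CC3)cc(C)c2c1` differs from compound 3 in one place: methyl in place of hydrogen on a saturated chain carbon bound to an aromatic carbon. For the measured compounds named here, the only measured step, a 1.8-fold lower number from compound 1 to compound 2 (0.25 log units; within the scatter), concerns a different place in the structure and stayed within the scatter; no measured pair touches the place changed here. With nothing pointing either way, a step no larger than the scatter is expected. Compound 4 is therefore estimated at 10000 nM, with a range of 4000 nM to 25000 nM. The expected step, a 1.1-fold lower number from compound 3 to compound 4 (0.04 log units; within the scatter), would remain within the scatter.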

Compound 4, half-maximal inhibitory concentration: 15800 nM
Compound 4: middle estimate off by 1.6-fold (0.20 log units), on the low side; measured number inside the range.
By their numbers in this assay, from the lowest: compounds 2 and 1 (each within the scatter of the next); then compounds 3 and 4 (each within the scatter of the next).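

In this assay, for the compounds shown here, the exchange of 2-methylphenyl for 2-ethylphenyl gives a 1.4-fold higher number from compound 3 to compound 4 (0.16 log units; within the scatter) and is the first measured step at this position. One added methyl on the saturated chain carbon bound to an aromatic carbon therefore leaves the number within the scatter, at the weak end of the set. No measurement shown offers an explanation for this result. The compounds leave open whether a longer chain, an amine or a carboxylic acid at this place would also stay within the scatter.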